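A few compounds are considered here, and "the series" means these few. Any claim that something is new, unique, unknown or untested is made for them only; others in the source may bear on it.

Two compounds share a core and differ in one side group. Compound 1, `CCOC(=O)c1csc([C@H]2[C@@H](COC)C[C@@](CC(C)C)(C(=O)O)N2C(=O)c2ccc(C(C)(C)C)c(OC)c2)n1`, was measured in an ADME assay on Huh-5-2 cells (Homo sapiens) for cytotoxicity, with a stated time of 3 days (a lower number here means that less compound is tolerated, a higher number that more compound is tolerated), where compound 1 gives 200000 nM. Compound 2, `COC[C@H]1C[C@@](CC(C)C)(C(=O)O)N(C(=O)c2ccc(C(C)(C)C)c(OC)c2)[C@H]1COC(=O)OC`, carries ((methoxycarbonyl)oxy)methyl in place of 4-(ethoxycarbonyl)-1,3-thiazol-2-yl on a saturated ring carbon. In this assay compound 2 reaches only a limit of the assay, not a number, namely > 120000 nM. The step that the limit leaves unreadable from compound 1 to compound 2 therefore cannot be read in size, because of the limit of > 120000 nM in this assay, at which 1 of the 2 values shown sits. Compound 3, `COC[C@H]1C[C@@](CC(C)C)(C(=O)O)N(C(=O)c2ccc(C(C)(C)C)c(OC)c2)[C@H]1CNC(C)=O`, has not been measured; it differs from compound 2 by acetamido in place of (methoxycarbonyl)oxy on a saturated chain carbon bound to a saturated ring carbon. Among the measured compounds shown here, only one measured step touches the same position of the core, and its size is hidden by the limit, so there is no measured guide to how acetamido in place of (methoxycarbonyl)oxy moves cytotoxicity. Both measured compounds are tolerated up to very high concentrations, and that alone shapes the expectation. The step that the limit leaves unreadable from compound 2 to compound 3 is expected to be small, or none beyond the scatter. Compound 3 is therefore estimated at 150000 nM, within a range from 60000 nM to 300000 nM.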

Compound 3, half-maximal cytotoxic concentration: > 120000 nM
Compound 3: only a limit was reported (the forecaster's own chance of this, stated with the estimate: 55%); the middle value does not contradict the limit.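

In this assay, neither step to compound 3 can be read in size, whether from compound 1 or from compound 2, because compound 3 also gives only a limit: the limit of > 120000 nM in this assay, at which 2 of the 3 values shown sit. The compounds shown leave open whether acetamido and (methoxycarbonyl)oxy differ at all in their effect on cytotoxicity.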